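Cyclohexyl Thioether Replacing the Ester Chain on a Vanilloid Antagonist

The source may hold more compounds than are shown below. What is called first, only, known or untested is meant among the compounds shown, and "the series" means these compounds.

Measured compounds:
Compound 1, `CC(C)CCSc1nc(C(F)(F)F)ccc1CNC(=O)C(C)c1ccc(NS(C)(=O)=O)c(F)c1`, 0.7 nM
Compound 2, `CC1CCN(CCCSc2nc(C(F)(F)F)ccc2CNC(=O)C(C)c2ccc(NS(C)(=O)=O)c(F)c2)CC1`, 2.9 nM
Compound 3, `COC(=O)CCSc1nc(C(F)(F)F)ccc1CNC(=O)C(C)c1ccc(NS(C)(=O)=O)c(F)c1`, 48.2 nM

In an assay on CHO-K1 cells for antagonist activity at transient receptor potential cation channel subfamily V member 1 (Homo sapiens), read by FLIPR (on this read-out lower numbers stand for stronger inhibition and higher numbers for weaker inhibition), compound 3 gives 48.2 nM, the highest number of the three: one gap is a 17-fold higher number from compound 2 to compound 3 (1.22 log units; beyond the scatter) and the other is a 69-fold higher number from compound 1 to compound 3 (1.84 log units; beyond the scatter). Both of its measured neighbours carry a carbon-rich group where compound 3 has the methoxycarbonyl on the saturated chain carbon two bonds along the chain from the sulfur.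

Compound 4, `CC1CCC(Sc2nc(C(F)(F)F)ccc2CNC(=O)C(C)c2ccc(NS(C)(=O)=O)c(F)c2)CC1`, has not yet been measured in this assay. It differs from compound 3 by 4-methylcyclohexyl in place of 2-(methoxycarbonyl)ethyl on a sulfur. Among the measured compounds shown here, no measured pair shows exactly this exchange of a chain for a ring on the sulfur. What bears on it are the two steps in which the methoxycarbonyl terminus arrived, a 69-fold higher number from compound 1 to compound 3 (1.84 log units; beyond the scatter) and a 17-fold higher number from compound 2 to compound 3 (1.22 log units; beyond the scatter), both large and both toward higher numbers; compound 4 removes that terminus and the whole chain with it, so the expectation is a step in the opposite direction. Compound 4 is therefore expected to show a 16-fold lower number from compound 3 to compound 4 (1.21 log units; beyond the scatter) in this assay. The estimated value for compound 4 is 3 nM, with a range from 0.7 nM to 15 nM.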

Compound 4, inhibition constant: 0.5 nM
Beside the measured number, compound 4's estimate is 6.0-fold (0.78 log units) above it, and the stated range ends above it.
By their numbers in this assay, from the lowest: compounds 4 and 1 (each within the scatter of the next); then compound 2; then compound 3.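

In this assay, the exchange of a chain for a ring on the sulfur costs nothing measurable against the best chain shown: a 1.4-fold lower number from compound 1 to compound 4 (0.15 log units; within the scatter) leaves 4-methylcyclohexyl and isopentyl indistinguishable, so an open chain is not required at this position. The other two steps, a 96-fold lower number from compound 3 to compound 4 (1.98 log units; beyond the scatter) and a 5.8-fold lower number from compound 2 to compound 4 (0.76 log units; beyond the scatter), extend what the earlier compounds showed: among these four compounds, the two groups on the sulfur built only of carbon give the lowest numbers, while the 3-(4-methylpiperidin-1-yl)propyl and 2-(methoxycarbonyl)ethyl groups give higher ones, with no compound here going against that pattern. Nothing available explains why these groups rank as they do, and the numbers alone cannot supply a reason.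

The compounds shown leave open whether the methyl on the ring matters at all, a question that plain cyclohexyl would answer, and whether a smaller ring such as cyclopentyl would serve equally well. They also do not tell whether a hydroxyl or an amine on the cyclohexyl ring would raise the number as the methoxycarbonyl terminus does on the chain.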